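Methyl added to the five-membered ring: compound 2 to compound 4

The source may report more compounds than this note shows. Statements on the series, on what has been measured and on what is new or still open speak of the compounds shown alone.

Compound 1 `Cc1cc(C)c(CN2CCc3ccc(O[C@@H]4CCOC4)c(Cl)c3C2=O)c(=O)[nH]1`: 512 nM
Compound 2 `Cc1cc(C)c(CN2CCc3c(Cl)cc(-c4cn[nH]c4)c(Cl)c3C2=O)c(=O)[nH]1`: 1580 nM
Compound 3 `Cc1cc(C)c(CN2CCc3ccc(OC(C)C)c(Cl)c3C2=O)c(=O)[nH]1`: 1160 nM

In a functional assay on KARPAS-422 cells (Homo sapiens) for inhibition, with a stated time of 72 h (a higher number here means a weaker inhibitor, a lower number a stronger inhibitor), compound 2 shows the highest of the three numbers. Compound 3 stands within the scatter of compound 2, whereas compound 1 stands beyond the scatter below it. Compound 4 `Cc1cc(C)c(CN2CCc3c(Cl)cc(-c4cn[nH]c4C)c(Cl)c3C2=O)c(=O)[nH]1` differs from compound 2 by methyl in place of hydrogen on an aromatic carbon. Among the measured compounds shown here, the only single-place step measured so far, a 2.3-fold higher number from compound 1 to compound 3 (0.36 log units; beyond the scatter), concerns the group on the oxygen on an aromatic ring and does not bear on this change. For the measured compounds named here, no measured step touches the 1H-pyrazol-4-yl group, so nothing beyond the scatter is expected from adding the methyl. Compound 4 is therefore estimated at 1500 nM, with a range of 600 nM to 4000 nM. The expected step of a 1.1-fold lower number from compound 2 to compound 4 (0.02 log units; within the scatter) lies within the scatter.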

Compound 4, half-maximal inhibitory concentration: 1340 nM
For compound 4 the middle estimate is 1.1-fold (0.05 log units) above the measured one; the range from low to high includes it.
By their numbers in this assay, from the lowest: compound 1; then compounds 3, 4 and 2 (each within the scatter of the next).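

In this assay, among the compounds shown here, the step of a 1.2-fold lower number from compound 2 to compound 4 (0.07 log units; within the scatter) is the first measured change on the 1H-pyrazol-4-yl group, and it places methyl on the aromatic carbon next to the ring nitrogen. Hydrogen and methyl at this place cannot be told apart in this assay, so a single added carbon here leaves the reading within the scatter. Nothing measured accounts for this result.

Open, going by these compounds, is whether a longer chain such as ethyl, or an aminomethyl or carboxylic acid group, at this carbon would give a step beyond the scatter. Also open, on these data alone, is whether methyl on the other ring carbon next to the ring nitrogen would behave as this one does.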